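This account rests on a few compounds, and the source may have more. Where it says the series, first, only, none or still open, it means among the compounds named here.

Compound 1, `C=C(Br)C(=O)Nc1cccc(-c2cn3nc(-c4ccc(C)cc4)sc3n2)c1`: in a functional assay on FM3A cells (Mus musculus) for inhibition, read by cell counting, with a stated time of 2 days (a lower number here means a stronger inhibitor, a higher number a weaker inhibitor), compound 1 gives 1200 nM.
Compound 2, `COc1ccc(-c2nn3cc(-c4cccc(N)c4)nc3s2)cc1`: in this assay compound 2 gives 74000 nM.

Of these two numbers compound 2 stands highest, and compound 1 gives the lower one. Compound 3, `Cc1ccc(-c2nn3cc(-c4cccc(N)c4)nc3s2)cc1`, differs from compound 2 by methyl in place of methoxy on an aromatic carbon. Among the compounds with values here, no pair of measured compounds shows this exchange, so nothing measured tells how large a step it brings. An exchange of one group for another at one aromatic carbon is expected to shift the number only modestly, in either direction, likely within the scatter. Compound 3 is therefore expected to give 60000 nM, within a range from 20000 nM to 200000 nM. The expected step is a 1.2-fold lower number from compound 2 to compound 3 (0.09 log units; within the scatter).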

Compound 3, half-maximal inhibitory concentration: 5800 nM
The estimate for compound 3 lay 10-fold (1.01 log units) above the measured number; measured number outside the range, below it.
By their numbers in this assay, from the lowest: compound 1; then compound 3; then compound 2.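

In this assay the aromatic carbon para to a large group proves sensitive: methyl in place of methoxy there brings a 13-fold lower number from compound 2 to compound 3 (1.11 log units; beyond the scatter) and so counts as a large step, not a minor exchange. Hydrogen in place of (1-bromoethenyl)carbonyl on the nitrogen brings a 4.8-fold higher number from compound 1 to compound 3 (0.68 log units; beyond the scatter) and is a modest step, so compound 3 keeps much of the strength of compound 1 without that group. From the compounds shown here alone, whether an ethyl group or a chlorine atom on the same carbon would give a number nearer compound 3 or compound 2 stays open. Nothing available accounts for the size of the methyl step.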